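The compounds below may be only part of what the source reports. "The series", "measured", "known", "first", "only" and "open" are said of these compounds alone.

Measured compounds: compound 1 `CCO/N=C/Nc1cc(Cl)cc(Cl)c1` with 3; compound 2 `CCO/N=C/Nc1cc(Cl)c(SSCC)c(Cl)c1` with 5; compound 3 `C#CCc1c(Cl)cc(N/C=N/OCC=C)cc1Cl` with 3.7, all in a physicochemical assay for lipophilicity, measured as octanol-water partition; a higher number here means a more lipophilic compound, a lower number a more polar compound.

Compound 3 stands second highest of the three, with compound 1 nearest and compound 2 furthest. Among the compounds with values here, the only measured step, a number 2.00 log units higher from compound 1 to compound 2 (beyond the scatter), concerns an aromatic position and a different group, so nothing measured bears directly on the change to compound 4 `C#CCc1c(Cl)cc(N/C=N/OCCOCC)cc1Cl`, which is ethoxymethyl in place of vinyl on a saturated chain carbon bound to an oxygen. The entering ethoxymethyl brings one more heavy atom and one hydrogen-bond acceptor than the leaving vinyl, and an estimate can rest only on those counts. Compound 4 is therefore expected to give 3.4, within 2.9 to 3.9, an estimated step of a number 0.30 log units lower from compound 3 to compound 4 (within the scatter) from compound 3, small and possibly within the scatter.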

Compound 4, partition coefficient: 3.7
Compound 4: middle estimate off by 0.30 log units, on the low side, and the stated range covers the measured number.
By their numbers in this assay, from the lowest: compound 1; then compounds 3 and 4 (each within the scatter of the next); then compound 2.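

In this assay, ethoxymethyl in place of vinyl on a saturated chain carbon bound to an oxygen gives no change at the digits printed from compound 3 to compound 4 (within the scatter), so this swap, despite the added heavy atoms and the hydrogen-bond acceptor, leaves the number in place. Within the data shown here, the only earlier step, a number 2.00 log units higher from compound 1 to compound 2 (beyond the scatter), concerned an aromatic carbon and said nothing about this position. No measured evidence accounts for this result.

As far as these compounds go, whether an amine, a carboxylic acid or a longer chain in place of ethoxymethyl would move the number remains open. So does whether the same swap reads alike on another core.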